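Removing the Furanylmethyl Group from a Piperazine Ligand

The source may report more compounds than this note shows. Statements on the series, on what has been measured and on what is new or still open speak of the compounds shown alone.

Compound 1 `c1coc(CN2CCN(CCCc3c[nH]c4ccc(-n5cnnc5)cc34)CC2)c1`: 0.4 nM
Compound 2 `CN(C)C(=O)C(c1ccccc1)N1CCN(CCCc2c[nH]c3ccc(-n4cnnc4)cc23)CC1`: 1 nM

Of the compounds shown here, two have been measured in an assay on CHO cells for displacement of a labelled ligand from 5-hydroxytryptamine receptor 1D (Homo sapiens); a higher number here means a weaker inhibitor, a lower number a stronger inhibitor. Compound 1 gives 0.4 nM, the lowest number of the two, and compound 2 gives 1 nM, a gap that lies beyond the usual scatter. Compound 1 is therefore the stronger inhibitor of the pair.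

Compound 3 `c1cc2[nH]cc(CCCN3CCNCC3)c2cc1-n1cnnc1` has not yet been measured. Its change from compound 1 is hydrogen in place of (furan-2-yl)methyl on an amine nitrogen in a ring, so the ring amine nitrogen carries only a hydrogen where compound 1 carries the larger group. Both measured compounds carry a sizeable group on that nitrogen, and both sit at very low numbers; nothing measured shows what happens when the nitrogen is left bare. A modest loss of potency, possibly beyond the scatter, seems the likelier outcome, expected as a 3.8-fold higher number from compound 1 to compound 3 (0.57 log units; beyond the scatter). Compound 3 is estimated at 1.5 nM, within a range from 0.4 nM to 6 nM.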

Compound 3, half-maximal inhibitory concentration: 31 nM
Compound 3: the middle estimate sits 21-fold (1.32 log units) below what was measured; measured number above the stated range.
By their numbers in this assay, from the lowest: compound 1; then compound 2; then compound 3.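

Leaving the ring nitrogen bare is not a minor edit: in this assay, putting hydrogen in place of (furan-2-yl)methyl gives a 78-fold higher number from compound 1 to compound 3 (1.89 log units; beyond the scatter) and counts as a large step, well beyond the scatter. The earlier compounds shown here both carried a sizeable group on this amine nitrogen, so they could not show how much the number depends on having a group there at all, and this single change now shows that dependence is strong. Nothing measured here bears on the reason for this loss.

The compounds shown do not tell whether the furan ring itself matters or whether almost any carbon group on that nitrogen would bring the number back down. A plain methyl, a benzyl or a longer carbon chain at the same nitrogen would separate those two possibilities.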